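Para-substituent shifts on a benzamide-bearing flavonol series

The source may report more compounds than this note shows. Statements on the series, on what has been measured and on what is new or still open speak of the compounds shown alone.

Compound 1 `O=C(Nc1cccc(-c2oc3cc(-c4ccc(F)cc4)ccc3c(=O)c2O)c1)c1ccccc1F`: 7570 nM
Compound 2 `O=C(Nc1cccc(-c2oc3cc(-c4ccc(F)cc4)ccc3c(=O)c2O)c1)c1ccc(F)cc1`: 8590 nM
Compound 3 `O=C(Nc1cccc(-c2oc3cc(-c4ccc(F)cc4)ccc3c(=O)c2O)c1)c1ccc(Br)cc1`: 24000 nM

In a functional assay on MCF7 cells (Homo sapiens) for antiproliferative activity, read by CCK-8 assay, with a stated time of 72 h (on this read-out higher numbers stand for weaker inhibition and lower numbers for stronger inhibition), compound 3 gives the highest of the three numbers, with a 3.2-fold higher number from compound 1 to compound 3 (0.50 log units; beyond the scatter) and a 2.8-fold higher number from compound 2 to compound 3 (0.45 log units; beyond the scatter) both beyond the scatter, while a 1.1-fold higher number from compound 1 to compound 2 (0.05 log units; within the scatter) stays within it. Compound 4 `COc1ccc(C(=O)Nc2cccc(-c3oc4cc(-c5ccc(F)cc5)ccc4c(=O)c3O)c2)c(F)c1` differs from compound 3 by 2-fluoro-4-methoxyphenyl in place of 4-bromophenyl on a carbonyl carbon. Among the compounds with values here, the steps that bear on it are the two that end at compound 3: replacing the 4-bromophenyl with a 4-fluorophenyl or a 2-fluorophenyl gave modestly lower numbers. Within the data shown here, compound 4 keeps a fluoro on the phenyl, as in compound 1, and adds a methoxy that no measured compound carries, so its effect is unknown. The expectation is therefore a modest return toward the numbers of compound 1 and compound 2, that is a 2.7-fold lower number from compound 3 to compound 4 (0.43 log units; beyond the scatter) in this assay. Compound 4 is estimated at 9000 nM, with a range from 3500 nM to 25000 nM.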

Compound 4, half-maximal inhibitory concentration: 20000 nM
Compound 4: middle estimate off by 2.2-fold (0.35 log units), on the low side, and the stated range covers the measured number.
By their numbers in this assay, from the lowest: compounds 1 and 2 (each within the scatter of the next); then compounds 4 and 3 (each within the scatter of the next).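

In this assay, methoxy entering on the fluorinated phenyl gives a 2.6-fold higher number from compound 1 to compound 4 (0.42 log units; beyond the scatter), so keeping a fluoro on this ring does not by itself keep the number near that of compound 1. The 2-fluoro-4-methoxyphenyl group also gives a 2.3-fold higher number from compound 2 to compound 4 (0.37 log units; beyond the scatter) when it replaces 4-fluorophenyl, yet a 1.2-fold lower number from compound 3 to compound 4 (0.08 log units; within the scatter) when it replaces 4-bromophenyl, so among these four compounds the methoxy-bearing group reads like the bromo-bearing one on this carbonyl carbon. No evidence is available that accounts for this shift.

The compounds shown leave open how a 4-methoxyphenyl group without the fluoro would read, so the shares of the methoxy and the fluoro in compound 4 cannot be separated. They also leave open whether an amine or a carboxylic acid on this phenyl would lower the number.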